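Replacing the pyrrolidine of compound 2 with an isopropyl-diazepane

A few compounds are considered here, and "the series" means these few. Any claim that something is new, unique, unknown or untested is made for them only; others in the source may bear on it.

Of the compounds shown here, two sharing a dichlorophenyl-triazole core have been measured in a functional assay for antagonist activity at P2X purinoceptor 7 (Homo sapiens), read by FLIPR and calcium flux; on this read-out lower numbers stand for stronger inhibition and higher numbers for weaker inhibition. Compound 1, `CS(=O)(=O)c1ccccc1CNc1ncnn1-c1cccc(Cl)c1Cl`, gives 20 nM in this assay. Compound 2, `Clc1cccc(-n2cnnc2NCc2cccnc2N2CCCC2)c1Cl`, gives 14.8 nM in this assay; its number and that of compound 1 lie within the scatter of each other, so the two cannot be told apart on these data.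

Compound 3, `CC(C)N1CCCN(c2ncccc2CNc2nncn2-c2cccc(Cl)c2Cl)CC1`, has not yet been measured. It differs from compound 2 in one place: 4-isopropyl-1,4-diazepan-1-yl in place of pyrrolidin-1-yl on an aromatic carbon. For the measured compounds named here, no measured pair shows a comparable change, so the size and direction of its effect cannot be read from the data at hand. The step from compound 2 to compound 3 is therefore expected to be small, a 1.4-fold higher number from compound 2 to compound 3 (0.13 log units; within the scatter), most likely not beyond the scatter in either direction. Compound 3 is accordingly estimated to give 20 nM in this assay, with a plausible range from 6 nM to 65 nM.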

Compound 3, half-maximal inhibitory concentration: 67.6 nM
The estimate for compound 3 lay 3.4-fold (0.53 log units) below the measured number; the whole stated range lies below it.
By their numbers in this assay, from the lowest: compounds 2 and 1 (each within the scatter of the next); then compound 3.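

In this assay this position, on an aromatic carbon next to the ring nitrogen, proves sensitive to the choice of cyclic amine: 4-isopropyl-1,4-diazepan-1-yl in place of pyrrolidin-1-yl gives a 4.6-fold higher number from compound 2 to compound 3 (0.66 log units; beyond the scatter) and so moves the number beyond the scatter. The step is modest, however, and the position still accepts the larger group, with a seven-membered ring and a second nitrogen, without the activity disappearing. Nothing at hand accounts for the rise in the number.

The change alters ring size, nitrogen count and the isopropyl substituent at once, so the compounds shown leave open which of these carries the step. A piperidin-1-yl group, or a 1,4-diazepan-1-yl group bearing methyl in place of isopropyl, would begin to separate these contributions.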